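The source may hold more compounds than are shown below. What is called first, only, known or untested is meant among the compounds shown, and "the series" means these compounds.

Compound 1 `COc1ccc([C@@H]2C(c3ccc(C)s3)C(=O)N2c2cc(OC)c(OC)c(OC)c2)cc1` stands lowest of the two numbers shown here. In a functional assay on MCF7 cells (Homo sapiens) for antiproliferative activity, read by MTT assay (on this read-out lower numbers stand for stronger inhibition and higher numbers for weaker inhibition), compound 1 gives 250 nM. Compound 2 `COc1ccc([C@@H]2/C(=C/c3cccs3)C(=O)N2c2cc(OC)c(OC)c(OC)c2)cc1` gives 4050 nM in this assay, a gap well beyond the usual scatter. Compound 3 `COc1ccc([C@@H]2C(c3cccs3)C(=O)N2c2cc(OC)c(OC)c(OC)c2)cc1` is not yet measured and differs from compound 1 in one place only: hydrogen in place of methyl on an aromatic carbon. Among the compounds with values here, no measured pair shows this exact change, so only a small step is expected, likely within the scatter, with a slight lean toward a weaker result. Compound 3 is therefore estimated at 400 nM, between 120 nM and 1500 nM. The step of a 1.6-fold higher number from compound 1 to compound 3 (0.20 log units; within the scatter) is expected to be modest.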

Compound 3, half-maximal inhibitory concentration: 64 nM
For compound 3 the middle estimate is 6.3-fold (0.80 log units) above the measured one; measured number outside the range, below it.
By their numbers in this assay, from the lowest: compound 3; then compound 1; then compound 2.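

Going from the 5-methylthiophen-2-yl group to thiophen-2-yl gives, in this assay, a 3.9-fold lower number from compound 1 to compound 3 (0.59 log units; beyond the scatter), so a single methyl on the aromatic carbon next to the ring sulfur matters, and the plain hydrogen gives the stronger inhibition here. Nothing available explains why the step runs in this direction. On these data alone, whether a chlorine atom, a methoxy group or an ethyl chain at this place would land nearer compound 3 or compound 1 remains open. So does whether the same step would hold on other cell lines.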